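Swapping the core aryl for pentan-3-yl: expected acidity

A few compounds are considered here, and "the series" means these few. Any claim that something is new, unique, unknown or untested is made for them only; others in the source may bear on it.

Compounds measured so far:
compound 1, `COc1cccc(CNCCCNc2ccnc3cc(-c4ccc(C(C)(C)C)cc4)ccc23)c1O`: 9.47
compound 2, `CC(C)(C)c1ccc(-c2ccc3c(NCCCNCc4ccco4)ccnc3c2)cc1`: 9.47
compound 3, `COc1ccc(F)cc1CNCCCNc1ccnc2cc(Oc3ccccc3)ccc12`: 9.28

The three compounds were tested in a physicochemical assay for acid dissociation. Compound 1 gives 9.47, level with compound 2 at the digits printed; together they are the highest of the three numbers. Compound 3 gives 9.28, a number lower than that of compound 1 but within the scatter.

Compound 4, `CCC(CC)c1ccc2c(NCCCNCc3cccc(OC)c3O)ccnc2c1`, has not yet been measured. It differs from compound 1 in one place: pentan-3-yl in place of 4-(tert-butyl)phenyl on an aromatic carbon. Within the data shown here, the only measured step between neighbours, no change at the digits printed from compound 1 to compound 2 (within the scatter), changes the group on the saturated chain carbon bound to the amine nitrogen and not the aromatic carbon of the core, so no measured step bears directly on this change. Among the measured compounds shown here, that step also showed no movement, and all three numbers so far lie within the scatter of each other. For compound 4 the step is therefore expected to be no larger than the scatter, a number 0.02 log units lower from compound 1 to compound 4 (within the scatter). Compound 4 is thus estimated at 9.45, within a range from 9.1 to 9.8.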

Compound 4, acid dissociation constant: 9.47
Compound 4: middle estimate off by 0.02 log units, on the low side, and the stated range covers the measured number.
By their numbers in this assay, from the lowest: compounds 3, 1, 2 and 4 (each within the scatter of the next).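

In this assay, the exchange of 4-(tert-butyl)phenyl for pentan-3-yl on an aromatic carbon of the shared core gives no change at the digits printed from compound 1 to compound 4 (within the scatter). Among these compounds, this is the first step measured at this position, and it shows that taking away the six-membered aromatic ring, going from 10 heavy atoms to 5, leaves the read-out level for this pair. Nothing measured here accounts for this outcome.

On these data alone, both groups hold carbon only, so it remains open whether a carboxylic acid, an amine or a nitrile on this aromatic carbon would also leave the number level. As far as these compounds go, it is also open whether the same exchange would give the same result with furan-2-yl in place of 2-hydroxy-3-methoxyphenyl on the chain, as in compound 2.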